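The source may hold more compounds than are shown below. What is called first, only, known or untested is meant among the compounds shown, and "the series" means these compounds.

Compound 1 `OB(c1ccc(C(F)(F)F)cc1)c1ccc(C(F)(F)F)cc1` — 10800 nM
Compound 2 `Fc1ccc([B-]2(c3ccc(F)cc3)[NH2+]CCO2)cc1` — 17000 nM
Compound 3 `Cc1ccc([B-]2(c3ccccc3)[NH2+]CCO2)cc1` — 18900 nM

All three were measured in an assay on HEK293 cells for inhibition of transient receptor potential cation channel subfamily V member 6 (Homo sapiens), read by FLIPR and calcium flux, with a stated time of 5 min; a higher number here means a weaker inhibitor, a lower number a stronger inhibitor. Compound 3, with 18900 nM, shows the largest number of the three. Its gap to compound 2 lies within the scatter, and so does its gap to compound 1, so the three compounds cannot be told apart on these numbers; compound 1, which carries a different core, gives 10800 nM, and compound 2 gives 17000 nM.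

Compound 4 `Brc1ccc([B-]2(c3ccccc3)[NH2+]CCO2)cc1` has not yet been measured in this assay. It differs from compound 3 in one place: bromo in place of methyl on an aromatic carbon. Going by the values given here, no pair of measured compounds shows this kind of exchange, so nothing in the data sets the size or direction of the step. The three measured compounds sit close together in spite of their differing substituents, which gives no ground to expect a step beyond the scatter. The step from compound 3 to compound 4 is therefore estimated as a 1.0-fold higher number from compound 3 to compound 4 (0.00 log units; within the scatter), with a wide range. Compound 4 is expected to give about 19000 nM, between 8000 nM and 45000 nM.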

Compound 4, half-maximal inhibitory concentration: 13200 nM
Compound 4: middle estimate off by 1.4-fold (0.16 log units), on the high side; low and high end bracket the measured number.
By their numbers in this assay, from the lowest: compounds 1, 4, 2 and 3 (each within the scatter of the next).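

In this assay, bromo in place of methyl on an aromatic carbon, para to a large group, gives a 1.4-fold lower number from compound 3 to compound 4 (0.16 log units; within the scatter), and this is the only step among the compounds shown that isolates a single position. It shows that this position holds either bromo or methyl with no change that can be told from the scatter, so the two groups cannot be separated on this read-out. No measurement shown offers any explanation for this step or bears on what the two groups do at this position.

On these data alone, what an amine, a carboxylic acid or a longer chain would give at this position remains open, as does whether any group there could move the number beyond the scatter. With a single pair, it is also unknown whether the same exchange would behave alike on the other aromatic ring.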